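The source may report more compounds than this note shows. Statements on the series, on what has been measured and on what is new or still open speak of the compounds shown alone.

Compound 1, `O=C(CCCCCCCNC(=O)C(O)(O)C(F)(F)F)Nc1ccccc1`, gives in a functional assay on HCT-116 cells (Homo sapiens) for inhibition, read by colorimetric assay, with a stated time of 3 days (a higher number here means a weaker inhibitor, a lower number a stronger inhibitor), a value of 41700 nM.
Compound 2, `CC(=O)C(=O)NCCCCCCC(=O)Nc1ccccc1`, reaches in this assay only the limit > 100000 nM.
Compound 3, `O=C(CCCCCCC(O)C(F)(F)F)Nc1ccccc1`, reaches in this assay only the limit > 40000 nM.

Compound 3 therefore stands at a limit, not at a number, and among the three values shown only compound 1 carries a number; the step that the two limits leave unreadable from compound 2 to compound 3 cannot be read, since both its ends are limits. Compound 4, `NC(=O)C(=O)NCCCCCCCC(=O)Nc1ccccc1`, differs from compound 3 as follows: ((carbamoylcarbonyl)amino)methyl in place of 2,2,2-trifluoro-1-hydroxyethyl on a saturated chain carbon, six bonds along the chain from a carbonyl carbon. Going by the values given here, the only measured step that touches this region of the chain is the unreadable one just named, so nothing of known size bears on the change. Compound 2, which also carries an amide-linked dicarbonyl group on the chain, sits at the limit of > 100000 nM in this assay, at which 1 of the 3 values shown sits, and compound 3 sits at the limit of > 40000 nM in this assay, at which 1 of the 3 values shown sits. On that basis compound 4 is expected to remain weak in this assay, with an estimate of 90000 nM and a range from 30000 nM to 250000 nM. This estimate for compound 4 means an expected step that the limit leaves unreadable from compound 3 to compound 4, which cannot be judged against the scatter because compound 3 is itself a limit.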

Compound 4, half-maximal inhibitory concentration: > 100000 nM
Compound 4: no number, only a limit; the forecaster's own chance of this, stated with the estimate: 65%; middle value at least 1.1-fold (0.04 log units) away from the limit.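

Going by these compounds alone, replacing 2,2,2-trifluoro-1,1-dihydroxyethyl with carbamoyl on a carbonyl carbon gives the first step of readable size in this assay, an at least 2.3-fold higher number from compound 1 to compound 4 (0.37 log units; beyond the scatter), so the trifluorinated end group of compound 1 goes with the only numbered value shown. Compound 4 stands at a limit: the limit of > 100000 nM in this assay, at which 2 of the 4 values shown sit. The steps joining compound 4 to compound 2 and compound 3 cannot be read, as both ends of each are limits, so the change on the saturated chain carbon has no measured size.

From the compounds shown here alone, how far compound 4 lies past its limit remains open, and so does whether compound 1 owes its value to the 2,2,2-trifluoro-1,1-dihydroxyethyl group alone. Nor do these compounds show what a carboxylic acid or a hydroxamic acid on that carbonyl carbon would give in this assay.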